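The source may hold more compounds than are shown below. What is called first, only, known or untested is meant among the compounds shown, and "the series" means these compounds.

Measured compounds in a functional assay for inhibition of sodium/hydrogen exchanger (Oryctolagus cuniculus); a lower number here means a stronger inhibitor, a higher number a weaker inhibitor:
Compound 1 `CCc1cc(Br)c(S(C)(=O)=O)cc1C(=O)N=C(N)N` gives 41 nM.
Compound 2 `CCN(CC)Cc1cc(Br)c(S(C)(=O)=O)cc1C(=O)N=C(N)N` gives 9500 nM.
Compound 3 `CCCCCc1cc(C)c(C(=O)N=C(N)N)cc1S(C)(=O)=O` gives 27 nM.

Compound 3 holds the lowest of the three numbers, yet compound 1 sits within the scatter of it, while compound 2 stands far higher. Compound 4 `Cc1cc(Sc2ccccc2)c(S(C)(=O)=O)cc1C(=O)N=C(N)N` differs from compound 3 by phenylsulfanyl in place of pentyl on an aromatic carbon. Going by the values given here, the only measured step, a 230-fold higher number from compound 1 to compound 2 (2.36 log units; beyond the scatter), concerns a saturated chain carbon bound to an aromatic carbon and does not bear directly on a change at an aromatic carbon. Compounds 1 and 3 do show that two quite different groups at that place give numbers within the scatter of each other. Compound 4 is therefore expected near 45 nM, with a range of 12 nM to 170 nM. The expected step of a 1.7-fold higher number from compound 3 to compound 4 (0.22 log units; within the scatter) would barely exceed the scatter.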

Compound 4, half-maximal inhibitory concentration: 14 nM
Beside the measured number, compound 4's estimate is 3.2-fold (0.51 log units) above it; measured number inside the range.
By their numbers in this assay, from the lowest: compounds 4, 3 and 1 (each within the scatter of the next, the first and the last beyond it); then compound 2.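

In this assay, phenylsulfanyl in place of pentyl on this aromatic carbon gives a 1.9-fold lower number from compound 3 to compound 4 (0.29 log units; within the scatter). This place therefore takes a group with a six-membered aromatic ring as well as an open chain, with no change in the number beyond the scatter. Nothing measured here accounts for how closely the two groups agree.

As far as these compounds go, whether an amine or a carboxylic acid at this aromatic carbon would keep the number in this range remains open. So does whether phenoxy, with oxygen in place of the sulfur, would match phenylsulfanyl.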